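The compounds below may be only part of what the source reports. "The series", "measured", "known", "first", "only" and "open" are said of these compounds alone.

Among the compounds with values here, compound 1 (`CS(=O)(=O)N1C[C@H](C(=O)Nc2ccc(Cl)cc2)[C@@H](C(=O)Nc2ccc(-n3ccccc3=O)cc2F)C1`) is the only compound in this small set with a number. In a physicochemical assay for lipophilicity, at pH 7.4 (a lower number here means a more polar compound, a higher number a more lipophilic compound), compound 1 gives 2.17. In this assay compound 2 (`CC(C)N1C[C@H](C(=O)Nc2ccc(Cl)cc2)[C@@H](C(=O)Nc2ccc(-n3ccccc3=O)cc2F)C1`) gives "not determined" (no result reported), and compound 3 (`O=C(Nc1ccc(Cl)cc1)[C@H]1CN(CC2CC2)C[C@@H]1C(=O)Nc1ccc(-n2ccccc2=O)cc1F`) gives "not determined" (no result reported). A single value cannot be ranked against anything, so it is not yet possible to say whether compound 1 sits high or low within the set. It serves only as a starting point.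

Compound 4 (`COc1ccc(NC(=O)[C@H]2CN(S(C)(=O)=O)C[C@@H]2C(=O)Nc2ccc(-n3ccccc3=O)cc2F)cc1Cl`) keeps the core of compound 1 and alters one piece: 3-chloro-4-methoxyphenyl in place of 4-chlorophenyl on an amide-type nitrogen. In plain terms, 3-chloro-4-methoxyphenyl appears in place of 4-chlorophenyl on an amide-type nitrogen, and the rest of the structure stays the same.

Within the data shown here, no measured pair in this set shows what a change of this kind does, so the expectation rests on the structural change alone. Among the measured compounds shown here, since the swap touches only one group, and that group keeps its chlorine and its aromatic ring, compound 4 is expected to stay close to compound 1 at 2.17. The expected change is a number 0.03 log units higher from compound 1 to compound 4 (within the scatter), with no clear direction and nothing beyond the usual scatter of repeated measurements. For compound 4 the estimate is 2.2, with an expected range from 1.8 to 2.6.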

Compound 4, distribution coefficient: 1.9
Estimate against measurement, compound 4: 0.30 log units above; the measured number falls inside the stated range.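

At this place, on an amide-type nitrogen, the aromatic ring can take on a methoxy group and change from 4-chlorophenyl to 3-chloro-4-methoxyphenyl, with a reading in this assay of a number 0.27 log units lower from compound 1 to compound 4 (within the scatter) and therefore no distinguishable difference between the two compounds. The entering group counts one hydrogen-bond acceptor where the leaving group counts none, yet this single pair gives no sign that such a swap moves the read-out beyond what repeated measurements would show. Within the data shown here, this is the first comparison in the set, so the number for compound 1 now has a neighbour, though nothing measured here explains why the two values are so alike.

One pair cannot show whether this place always tolerates change in this assay, and a phenyl ring bearing a carboxylic acid or an amine in place of the methoxy group could behave quite differently. Compound 2 and compound 3 have no reported number, so the effect of changing the group on the other nitrogen of the shared core cannot be read.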